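This account rests on a few compounds, and the source may have more. Where it says the series, first, only, none or still open, it means among the compounds named here.

Of the compounds shown here, two of a shared core have been tested in a functional assay on SN12C cells (Homo sapiens) for inhibition, read by sulforhodamine B assay, with a stated time of 48 h (on this read-out lower numbers stand for higher toxicity in this test and higher numbers for lower toxicity in this test), and both reach the edge of what the test can report. Compound 1 `COc1cc(-c2nn(-c3cccc(NC(=O)Nc4cc(C(F)(F)F)cc(C(F)(F)F)c4)c3)cc2-c2ccncc2)ccc1Cl` gives in this assay a value that is a limit, > 50000 nM, and so sits at the limit of > 50000 nM in this assay, at which 1 of the 2 values shown sits. Compound 2 `O=C(Nc1cccc(-n2cc(-c3ccncc3)c(-c3ccc(Cl)c(O)c3)n2)c1)Nc1ccc(Cl)c(Cl)c1` likewise gives in this assay only a limit, > 32500 nM, which is the limit of > 32500 nM in this assay, at which 1 of the 2 values shown sits. Compound 1 therefore stands at a limit, and the other value shown is a limit as well, so no ranking between the two can be drawn from these numbers.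

Compound 3 `COc1cc(-c2nn(-c3cccc(NC(=O)Nc4cccc(C(F)(F)F)c4)c3)cc2-c2ccncc2)ccc1Cl` has not yet been measured in this assay. It differs from compound 1 in one place: hydrogen in place of trifluoromethyl on an aromatic carbon. Among the compounds with values here, no measured step between compounds of this set exists to gauge the effect of such a change, and the numbers known for compound 1 and compound 2 are both limits. The expectation is that the step that the limit leaves unreadable from compound 1 to compound 3 will be none beyond the scatter, with compound 3 most likely also reported only as a limit. Compound 3 is thus estimated to give about 60000 nM in this assay, within a range from 20000 nM to 200000 nM.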

Compound 3, concentration lethal to 50% of the cells: > 50000 nM
Compound 3: no number, only a limit (the forecaster's own chance of this, stated with the estimate: 80%); the middle value lies beyond the limit too.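

In this assay compound 3 gives > 50000 nM, which is a limit and not a number. Compound 1 also stands at a limit, so the step between compound 1 and compound 3 cannot be read. The compounds shown leave open whether hydrogen in place of trifluoromethyl on an aromatic carbon has any effect in this assay.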